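The source may report more compounds than this note shows. Statements on the series, on what has been measured and on what is new or still open speak of the compounds shown alone.

Compound 1 `O=C(O)CN1C(=O)/C(=C/c2nc3ccccc3n2Cc2ccc([N+](=O)[O-])cc2)SC1=S` stands at the top of the three numbers gathered so far: in a functional assay on A549 cells (Homo sapiens) for cytotoxicity, read by MTT assay, with a stated time of 48 h (a lower number here means a stronger inhibitor, a higher number a weaker inhibitor), compound 1 gives 11400 nM. Its two companions are compound 2 `O=C(O)CN1C(=O)/C(=C/c2nc3ccccc3n2Cc2ccc(F)cc2)SC1=S`, which in this assay gives 3570 nM, and compound 3 `Cc1ccc(Cn2c(/C=C3\SC(=S)N(CC(=O)O)C3=O)nc3ccccc32)cc1`, which in this assay gives 3220 nM. Both changes already made at the same aromatic carbon lowered the number: a 3.2-fold lower number from compound 1 to compound 2 (0.50 log units; beyond the scatter) and a 3.5-fold lower number from compound 1 to compound 3 (0.55 log units; beyond the scatter). Between the two replacements themselves the gap is small, a 1.1-fold lower number from compound 2 to compound 3 (0.04 log units; within the scatter). Compound 4 `O=C(O)CN1C(=O)/C(=C/c2nc3ccccc3n2Cc2ccc(C(F)(F)F)cc2)SC1=S` makes a further exchange at that carbon: trifluoromethyl in place of nitro on an aromatic carbon. The two earlier steps away from compound 1 are the ones that bear on this, and each was a modest drop of much the same size, with no sign that the choice of entering group mattered. A drop of that order is therefore expected again, estimated as a 3.0-fold lower number from compound 1 to compound 4 (0.48 log units; beyond the scatter). Compound 4 is accordingly expected to give about 3800 nM in this assay, within a range from 1400 nM to 11000 nM.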

Compound 4, half-maximal inhibitory concentration: 25300 nM
Compound 4: middle estimate off by 6.7-fold (0.82 log units), on the low side; measured number outside the range, above it.
By their numbers in this assay, from the lowest: compounds 3 and 2 (each within the scatter of the next); then compound 1; then compound 4.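

At this position the direction of the step depends on the entering group: in this assay trifluoromethyl is the only replacement of nitro shown that raises the number (a 2.2-fold higher number from compound 1 to compound 4 (0.35 log units; beyond the scatter)), whereas fluoro and methyl both lowered it. Trifluoromethyl also sets compound 4 far from the other two replacements (a 7.9-fold higher number from compound 3 to compound 4 (0.90 log units; beyond the scatter); a 7.1-fold higher number from compound 2 to compound 4 (0.85 log units; beyond the scatter)), although those two lie within the scatter of each other, so the choice of group on this carbon matters in a way the earlier compounds gave no sign of. Nothing at hand accounts for this order of the four compounds.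

The compounds shown leave open where an amine, a methoxy group or a nitrile on this carbon would fall in that order, and so whether trifluoromethyl stands alone. They also leave open whether a longer chain such as ethyl would behave like methyl here.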